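A few compounds are considered here, and "the series" means these few. Any claim that something is new, unique, unknown or untested is made for them only; others in the source may bear on it.

Measured so far:
- compound 1 `Nc1ccccc1NC(=O)CCCNCC(=O)Nc1cccc([N+](=O)[O-])c1` gives 40.6%
- compound 2 `Nc1ccccc1NC(=O)CCCNCC(=O)Nc1cc(Cl)ccc1Cl` gives 50%
- compound 3 `Nc1ccccc1NC(=O)CCCNCC(=O)Nc1ccccc1Cl` gives 21.4%

These numbers come from a functional assay on the whole organism (Ehrlich cells, Mus musculus) for antiproliferative activity, with a stated time of 24 h, at a dose of 0.2 mmol/kg by the intraperitoneal route; a higher number here means more inhibition at the dose given (going by the name of the read-out), a lower number less inhibition. Compound 3 stands lowest of the three: the step of a number 19.2 percentage points lower from compound 1 to compound 3 (beyond the scatter) and the step of a number 28.6 percentage points lower from compound 2 to compound 3 (beyond the scatter) both lie beyond the scatter, so the 2-chlorophenyl group on the amide-type nitrogen gave the least inhibition seen. Compound 4 `COc1ccc(NC(=O)CNCCCC(=O)Nc2ccccc2N)cc1` differs from compound 3 in one place: 4-methoxyphenyl in place of 2-chlorophenyl on an amide-type nitrogen. For the measured compounds named here, no measured compound carries a 4-methoxyphenyl group, so there is no direct guide. The two steps that bear on the change are those into compound 3 above, and both show that changing the aryl group on this nitrogen moved the number by a modest amount, in each case upward from compound 3. Compound 4 is therefore expected to give a modestly higher number, a number 13.6 percentage points higher from compound 3 to compound 4 (beyond the scatter), with an estimate of 35% and a range from 15% to 55%.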

Compound 4, a percentage reported as inhibition, in the whole organism at one dose (the size of the read-out at that dose, not a potency): 63.8%
The estimate for compound 4 lay 28.8 percentage points below the measured number; the whole stated range lies below it.
By their numbers in this assay, from the lowest: compound 3; then compounds 1 and 2 (each within the scatter of the next); then compound 4.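

For the compounds shown here, changing the aryl group on this amide-type nitrogen can move inhibition much further than the earlier compounds showed, with a number 42.4 percentage points higher from compound 3 to compound 4 (beyond the scatter) the only large step so far. The 4-methoxyphenyl group also clears the two better earlier groups, with a number 13.8 percentage points higher from compound 2 to compound 4 (beyond the scatter) and a number 23.2 percentage points higher from compound 1 to compound 4 (beyond the scatter), which places compound 4 highest of the four.

Because this change swaps both the substituent and its ring position, the compounds shown cannot separate those two effects. A 4-chlorophenyl or 2-methoxyphenyl group at this nitrogen would address that question. No measurement here explains the rise.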